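This account rests on a few compounds, and the source may have more. Where it says the series, first, only, none or still open, it means among the compounds named here.

For the measured compounds named here, in a functional assay on HCT-116 cells (Homo sapiens) for antiproliferative activity, read by MTT assay, with a stated time of 72 h (on this read-out lower numbers stand for stronger inhibition and higher numbers for weaker inhibition), three compounds have numbers so far. Compound 1 `CC(C)(C)c1ccc(OCCCON2C(N)=NC(N)=NC23CCSCC3)cc1` gives 1 nM, compound 3 `NC1=NC2(CCSCC2)N(OCCCOc2cc(Cl)c(Cl)cc2Cl)C(N)=N1` gives 1 nM, and compound 2 `NC1=NC2(CCOCC2)N(OCCCOc2cccc(Cl)c2Cl)C(N)=N1` gives 5 nM. Compound 2 therefore stands highest of the three, and its gap to each of the other two lies beyond the scatter. No two of these compounds differ in one place only, so the data offer no direct step to lean on.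

Compound 4 `NC1=NC2(CCOCC2)N(OCCCOc2ccc(Cl)c(Cl)c2)C(N)=N1` has not yet been measured. It has the same atoms as compound 2, joined differently: 3,4-dichlorophenyl in place of 2,3-dichlorophenyl on an oxygen on a saturated carbon. In words, 3,4-dichlorophenyl stands in place of 2,3-dichlorophenyl on an oxygen on a saturated carbon. In this assay, this exchange is expected to produce no step beyond the scatter, with a slight lean towards a lower number. That lean is only a tentative expectation: compound 2 at 5 nM sits above both other measured compounds, and a new compound sharing its core has more room to fall than to rise. The estimated change is a 1.7-fold lower number from compound 2 to compound 4 (0.22 log units; within the scatter). For compound 4 the expected value is 3 nM, with an estimated range from 1 nM to 10 nM.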

Compound 4, half-maximal inhibitory concentration: 90 nM
Estimate against measurement, compound 4: 30-fold (1.48 log units) below; the whole stated range lies below it.
By their numbers in this assay, from the lowest: compounds 1 and 3 (each within the scatter of the next); then compound 2; then compound 4.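

In this assay, for the compounds shown here, 3,4-dichlorophenyl in place of 2,3-dichlorophenyl on an oxygen on a saturated carbon gives an 18-fold higher number from compound 2 to compound 4 (1.26 log units; beyond the scatter), and this is the first direct step, as the earlier compounds offered no pair differing in one place only. The two groups have the same heavy atoms and the same counts of donors, acceptors and charge, so at this place the arrangement of the two chlorines on the ring, and not just their presence, is enough to produce a large step on this core. The data shown give no measurement that accounts for the size of this step, so its origin remains unexplained.

The compounds shown leave open whether the same exchange would produce a step of similar size on the core of compound 1, as this single pair tests it only on the core shared by compound 2 and compound 4. They also leave open where an unsubstituted phenyl or a dimethoxyphenyl would fall at this place relative to these two dichlorophenyl groups, and whether a longer chain would change the size of the step.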